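Replacing the 3-fluoro-4-hydroxyphenyl group of compound 2

A few compounds are considered here, and "the series" means these few. Any claim that something is new, unique, unknown or untested is made for them only; others in the source may bear on it.

In a functional assay on HepG2 cells (Homo sapiens) for antiproliferative activity, read by sulforhodamine B assay, with a stated time of 48 h (on this read-out lower numbers stand for stronger inhibition and higher numbers for weaker inhibition), compound 2 `COc1ccc(OC)c(/C=C/C(=O)C(=Cc2ccc(O)c(F)c2)C(=O)/C=C/c2cc(OC)ccc2OC)c1` gives 220 nM and compound 1 `COc1ccc(OC)c(/C=C/C(=O)C(=Cc2ccc(O)c(OC)c2)C(=O)/C=C/c2cc(OC)ccc2OC)c1` gives 340 nM on the same scale. These two values lie within the scatter of each other, so compound 2 does not stand clearly apart from compound 1.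

Compound 3 `COc1ccc(OC)c(/C=C/C(=O)C(=Cc2cc(OC)c(O)c(OC)c2)C(=O)/C=C/c2cc(OC)ccc2OC)c1` keeps the shared core and differs from compound 2 at one place. The difference is 4-hydroxy-3,5-dimethoxyphenyl in place of 3-fluoro-4-hydroxyphenyl on a double-bonded chain carbon bound to a double-bonded chain carbon with 4-hydroxy-3,5-dimethoxyphenyl in place of 3-fluoro-4-hydroxyphenyl on a double-bonded chain carbon bound to a double-bonded chain carbon.

Within the data shown here, only one measured step bears on this change. It is fluoro in place of methoxy on an aromatic carbon, a 1.5-fold lower number from compound 1 to compound 2 (0.19 log units; within the scatter) and so no larger than the scatter. Among the measured compounds shown here, no measured compound carries the entering group, so this small step is a limited guide.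

A step beyond the scatter is therefore not expected in this assay and the estimated change is a 1.4-fold higher number from compound 2 to compound 3 (0.13 log units; within the scatter) as a modest move at most. Compound 3 is expected at 300 nM with an estimated range from 120 nM to 750 nM as its likely span.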

Compound 3, half-maximal inhibitory concentration: 210 nM
Compound 3: the middle estimate sits 1.4-fold (0.15 log units) above what was measured; measured number inside the range.
By their numbers in this assay, from the lowest: compounds 3, 2 and 1 (each within the scatter of the next).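

In this assay, 4-hydroxy-3,5-dimethoxyphenyl in place of 3-fluoro-4-hydroxyphenyl on a double-bonded chain carbon bound to a double-bonded chain carbon gives (a 1.0-fold lower number from compound 2 to compound 3 (0.02 log units; within the scatter)), so this position accepts the entering group, with its 11 heavy atoms and 3 hydrogen-bond acceptors, without a step beyond the scatter. The methoxy in place of hydrogen on an aromatic carbon gives (a 1.6-fold lower number from compound 1 to compound 3 (0.21 log units; within the scatter)), which also stays within the scatter. Together with the earlier fluoro step, this shows that the three groups carried at this place by compound 1, compound 2 and compound 3 cannot be told apart on this read-out, a wider range of change than the single earlier step covered. Nothing measured on these groups bears on this result.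

From the compounds shown here alone, all three groups keep the hydroxy, so it remains open whether a ring with an amine or a carboxylic acid in place of that hydroxy would also stay within the scatter. The rest of the shared core is the same in all three compounds, which leaves open how much changes made there would move the number.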